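Allylamide series: toxicity after halogen removal, working notes

The source may report more compounds than this note shows. Statements on the series, on what has been measured and on what is new or still open speak of the compounds shown alone.

Measured so far:
compound 1 `C=CCNC(=O)/C(C)=C(/C)c1ccc(Br)cc1` — 400 mg/kg
compound 2 `C=CCNC(=O)/C(C)=C(/C)c1ccc(Cl)cc1` — 180 mg/kg

Among the measured compounds shown here, in a toxicity assay on the whole organism (strain Icem-CET (SPF Caw)) for cytotoxicity, with Mus musculus as the target (on this read-out lower numbers stand for an effect already at smaller amounts and higher numbers for an effect only at larger amounts of compound), compound 2 gives 180 mg/kg, the lowest of the two numbers known so far; its nearest neighbour is compound 1, which gives 400 mg/kg. Compound 3 `C=CCNC(=O)/C(C)=C(/C)c1ccccc1` is not yet measured. It differs from compound 2 in a single place: hydrogen in place of chloro on an aromatic carbon, on an aromatic carbon of a six-membered aromatic ring of carbon only, para to a large group.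

For the measured compounds named here, the only measured step that touches this position is a 2.2-fold lower number from compound 1 to compound 2 (0.35 log units; beyond the scatter). Going by the values given here, that step exchanges one halogen for another; no measured pair shows what removing the halogen altogether does, so the guide is indirect. The halogen exchange moved this assay by a modest step, and a step of comparable size is the most that can be expected here, in either direction, with a wide range to cover the absence of a direct precedent.

The estimate for compound 3 is 200 mg/kg, with a range from 90 mg/kg to 450 mg/kg. This estimate amounts to an expected step of a 1.1-fold higher number from compound 2 to compound 3 (0.05 log units; within the scatter).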

Compound 3, dose for half-maximal effect: 550 mg/kg
The estimate for compound 3 lay 2.8-fold (0.44 log units) below the measured number; measured number above the stated range.
By their numbers in this assay, from the lowest: compound 2; then compounds 1 and 3 (each within the scatter of the next).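

Hydrogen in place of chloro gives a 3.1-fold higher number from compound 2 to compound 3 (0.49 log units; beyond the scatter) in this assay, the first direct reading of what losing the halogen does at this aromatic carbon. Hydrogen in place of bromo gives a 1.4-fold higher number from compound 1 to compound 3 (0.14 log units; within the scatter), so the two steps differ in kind: among the three compounds, only the chloro compound stands apart, and compound 1 goes against any reading in which a halogen at this place simply lowers the number. The series therefore shows an effect tied to chloro within these three compounds and not to halogen as a class, while the available data offer no information on the reason for it.

From the compounds shown here alone, whether fluoro, methyl or an amine on this carbon would fall with compound 2 or with compound 1 and compound 3 remains open. Also open, going by these compounds, is whether the chloro step persists with a longer chain in place of the allyl group on the amide, or with chloro at another carbon of the six-membered aromatic ring.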